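Adding a carbonyl to the piperazine of compound 3

The compounds below may be only part of what the source reports. "The series", "measured", "known", "first", "only" and "open" are said of these compounds alone.

In an ADME assay on microsomes from liver (Mus musculus) for metabolic stability, read by LC-MS, using NADPH, with stated times of 10 min and 30 min, tested at 1 uM (on this read-out higher numbers stand for fast clearance and lower numbers for slow clearance), compound 1 (`COC(=O)C1=C(C)NC(c2nccs2)=NC1(C)c1ccc(Cl)cc1`) gives 85 mL/min/kg and compound 2 (`COC(=O)C1=C(C)NC(c2nccs2)=NC1(C)c1ccc(F)c(F)c1`) gives 83 mL/min/kg on the same scale. Compound 3 (`COC(=O)C1=C(CN2CCNCC2)NC(c2nccs2)=NC1(C)c1ccc(F)cc1`) gives 39 mL/min/kg as the lowest of the three numbers, beyond the scatter from both others. Compound 4 (`COC(=O)C1=C(CN2CCNC(=O)C2)NC(c2nccs2)=NC1(C)c1ccc(F)cc1`) differs from compound 3 in one place (3-oxopiperazin-1-yl in place of piperazin-1-yl on a saturated chain carbon bound to a double-bonded ring carbon) with 3-oxopiperazin-1-yl in place of piperazin-1-yl on a saturated chain carbon bound to a double-bonded ring carbon. Going by the values given here, the only measured step (a 1.0-fold lower number from compound 1 to compound 2 (0.01 log units; within the scatter)) lies within the scatter and concerns a group on a saturated ring carbon, so it says nothing about this change. No step beyond the scatter is therefore expected, and the estimated step is a 1.0-fold higher number from compound 3 to compound 4 (0.01 log units; within the scatter) in this assay (a wide range applies). The estimate for compound 4 is 40 mL/min/kg with 20 mL/min/kg and 75 mL/min/kg as the expected ends of its range.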

Compound 4, clearance: 81 mL/min/kg
Beside the measured number, compound 4's estimate is 2.0-fold (0.31 log units) below it, and the stated range ends below it.
By their numbers in this assay, from the lowest: compound 3; then compounds 4, 2 and 1 (each within the scatter of the next).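

In this assay the change gives a 2.1-fold higher number from compound 3 to compound 4 (0.32 log units; beyond the scatter) and so shows that this position responds: one carbonyl on the piperazine, with the ring size and the counted hydrogen-bond donors and acceptors unchanged, moves clearance beyond the scatter. Going by these compounds alone, the only earlier step concerned a group on a saturated ring carbon, so this is the first reading at the saturated chain carbon. Nothing available explains the rise.

Open, going by these compounds, is how other groups at this place would read, such as morpholin-4-yl, dimethylamino or a carboxylic acid. Also open, on these data alone, is whether the same carbonyl would give a similar step with another group on the shared core.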